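Nitrophenyl position in a thiosemicarbazone series

The source may report more compounds than this note shows. Statements on the series, on what has been measured and on what is new or still open speak of the compounds shown alone.

Compound 1 `CC1=CC[C@@H]([C@@](C)(O)CCCC(C)(C)NC(=S)N/N=C\c2ccccc2)CC1` carries an unsubstituted phenyl on the carbon with a double bond to nitrogen; in a functional assay on PCO3 cells (Homo sapiens) for cytotoxicity, read by sulforhodamine B assay (on this read-out lower numbers stand for stronger inhibition of growth and higher numbers for weaker inhibition of growth), compound 1 gives 8470 nM. Compound 2 `CC1=CC[C@@H]([C@@](C)(O)CCCC(C)(C)NC(=S)N/N=C\c2cccc([N+](=O)[O-])c2)CC1` adds a nitro group to that ring, and in this assay compound 2 gives 5600 nM. The only measured step, a 1.5-fold lower number from compound 1 to compound 2 (0.18 log units; within the scatter), is within the scatter, so compound 2 and compound 1 cannot be told apart on the numbers shown, although compound 2 holds the lower of the two.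

Compound 3 `CC1=CC[C@@H]([C@@](C)(O)CCCC(C)(C)NC(=S)N/N=C\c2ccc([N+](=O)[O-])cc2)CC1` keeps every atom of compound 2 and moves the nitro group: 4-nitrophenyl in place of 3-nitrophenyl on a carbon with a double bond to nitrogen. Going by the values given here, no measured step changes the position of a group on this ring, so nothing here bears directly on the change; the one step that touches the ring, from compound 1 to compound 2, stayed within the scatter. The step of no change at the digits printed from compound 2 to compound 3 (within the scatter) is therefore expected to be none beyond the scatter, in no fixed direction. For compound 3 the estimate in this assay is 5600 nM, with a range from 2500 nM to 12500 nM.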

Compound 3, concentration for 50% growth inhibition: 18100 nM
The estimate for compound 3 lay 3.2-fold (0.51 log units) below the measured number; the measured number lies above the stated range.
By their numbers in this assay, from the lowest: compounds 2 and 1 (each within the scatter of the next); then compound 3.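

Position on the ring now counts in this assay: with the atoms unchanged, 4-nitrophenyl in place of 3-nitrophenyl gives a 3.2-fold higher number from compound 2 to compound 3 (0.51 log units; beyond the scatter), a modest step beyond the scatter, whereas the earlier compounds showed no step beyond it. Adding a nitro group to the phenyl therefore no longer reads as a change without consequence, since a 2.1-fold higher number from compound 1 to compound 3 (0.33 log units; beyond the scatter) also lies beyond the scatter, while the 3-nitrophenyl of compound 2 remains within the scatter of the phenyl of compound 1, so the outcome depends on where the nitro group stands, and compound 3 is the weakest of the three on this read-out. Nothing available explains this dependence on position.

On these data alone, whether an amine or a carboxylic acid in place of the nitro group would show the same dependence on ring position stays open, so the result cannot yet be extended beyond the nitro group. Also open, as far as these compounds go, is whether the step from 3-nitrophenyl to 4-nitrophenyl would hold on a different cell line or with a longer chain on the shared core.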